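The compounds below may be only part of what the source reports. "The series", "measured", "known", "first", "only" and "open" are said of these compounds alone.

Compound 2 `COCC(C)Oc1cccc2ccc(N)nc12` stands second highest of the three numbers measured in an assay on cells with melanin-concentrating hormone receptor 1 (Homo sapiens) as the target, read by radioligand binding (on this read-out lower numbers stand for stronger inhibition and higher numbers for weaker inhibition), where compound 2 gives 606 nM. Compound 1 `CC1CCCC(Oc2cccc3ccc(N)nc23)C1` gives 640 nM, a gap to compound 2 that lies within the usual scatter, so no order is read between the two. Within the data shown here, compound 3 `CCC(C)COc1cccc2ccc(N)nc12` gives 36 nM; the step of a 17-fold lower number from compound 2 to compound 3 (1.23 log units; beyond the scatter) is the only measured step at the same position as the change now considered, and it was large. Compound 4 `Nc1ccc2cccc(OCC3CC3)c2n1` differs from compound 2 as follows: cyclopropylmethyl in place of 1-(methoxymethyl)ethyl on an oxygen on an aromatic ring. Among the measured compounds shown here, the entering group, like the 2-methylbutyl of compound 3, carries no hydrogen-bond acceptor, and the one measured change of that kind at this oxygen gave a much lower number; cyclopropylmethyl is however a smaller group than 2-methylbutyl, so the full size of that step is not assumed. A step toward a lower number, beyond the scatter but shorter than the step to compound 3, is therefore expected: a 6.1-fold lower number from compound 2 to compound 4 (0.78 log units; beyond the scatter). For compound 4 the estimated value in this assay is 100 nM, within a range from 30 nM to 350 nM.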

Compound 4, half-maximal inhibitory concentration: > 2000 nM
Compound 4 gave a limit, no number (the forecaster's own chance of this, stated with the estimate: 2%); at least 20-fold (1.30 log units) between middle value and limit.
By their numbers in this assay, from the lowest: compound 3; then compounds 2 and 1 (each within the scatter of the next). At a limit, above all of these: compound 4.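

In this assay compound 4 stands only as a limit, not a number: the limit of > 2000 nM in this assay, at which 1 of the 4 values shown sits. Taking away the hydrogen-bond acceptor of 1-(methoxymethyl)ethyl does not by itself give a lower number at this oxygen on an aromatic ring: the change shows an at least 3.3-fold higher number from compound 2 to compound 4 (0.51 log units; beyond the scatter) and so runs opposite to the step to compound 3. Two entering groups without an acceptor also part widely, with an at least 55-fold higher number from compound 3 to compound 4 (1.74 log units; beyond the scatter) on going from sec-butyl to cyclopropyl on a saturated chain carbon bound to that oxygen, so the absence of an acceptor does not decide the outcome here.

From the compounds shown here alone, whether a straight pentyl chain or a cyclobutylmethyl on this oxygen would fall with compound 3 or with compound 4 stays open. Also open, going by these compounds, is how far compound 4 lies past its limit, so the full size of both steps remains unknown.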